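This account rests on a few compounds, and the source may have more. Where it says the series, first, only, none or still open, it means among the compounds named here.

Measured so far:
Compound 1, `C[C@H](c1ccccc1)n1cnc2c(N(C)C)ncnc21`, gives 33%.
Compound 2, `CC(C)N(C)c1ncnc2c1ncn2Cc1ccccc1`, gives 17%.

In a functional assay on the whole organism for inhibition, with Rattus norvegicus as the target, in the maximal electroshock model, at a dose of 25 mg/kg by the intraperitoneal route (a lower number here means less inhibition, a higher number more inhibition at the dose given (going by the name of the read-out)), compound 2 stands at the lowest of the two numbers; its nearest neighbour is compound 1, which lies higher by a gap beyond the usual scatter. Compound 3, `Oc1ncnc2c1ncn2Cc1ccccc1`, differs from compound 2 in one place: hydroxy in place of isopropyl(methyl)amino on an aromatic carbon. Among the measured compounds shown here, no step between measured compounds exists that could guide the size of this change. Because compound 2 already reads 17%, little room remains downward, so the step expected is small and within the scatter, a number 7 percentage points lower from compound 2 to compound 3 (within the scatter). Compound 3 is therefore estimated at 10%, with a range from 0% to 30%.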

Compound 3, a percentage reported as inhibition, in the whole organism at one dose (the size of the read-out at that dose, not a potency): 17%
Compound 3: middle estimate off by 7 percentage points, on the low side; the measured number falls inside the stated range.
By their numbers in this assay, from the lowest: compounds 2 and 3 (each within the scatter of the next); then compound 1.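

In this assay, hydroxy in place of isopropyl(methyl)amino on this aromatic carbon gives no change at the digits printed from compound 2 to compound 3 (within the scatter), the first step read at this position. Exchanging a group of five heavy atoms and no hydrogen-bond donor for one of a single oxygen and one donor thus leaves the read-out within the scatter at this dose. Nothing measured here bears on why the read-out stays put. From the compounds shown here alone, whether an unsubstituted amine, a methoxy group or a longer chain at this position would read differently stays open, and so does how this step behaves with the other substituent on the ring nitrogen carried by compound 1.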